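This account rests on a few compounds, and the source may have more. Where it says the series, first, only, none or still open, it means among the compounds named here.

Measured compounds:
Compound 1, `CCCCCCCc1nc(N)n(CC(=O)Nc2ccccc2)c1-c1ccccc1Br`, gives 7900 nM in a functional assay on MIA PaCa-2 cells (Homo sapiens) for antiproliferative activity, read by MTT assay, with a stated time of 48 h; on this read-out lower numbers stand for stronger inhibition and higher numbers for weaker inhibition.
Compound 2, `CCCCCc1nc(N)n(CC(=O)Nc2ccc(C)cc2)c1-c1ccccc1Br`, gives 5600 nM in this assay.
Compound 3, `CCCCCCc1nc(N)n(CC(=O)Nc2ccc(C)cc2)c1-c1ccccc1Br`, gives 6500 nM in this assay.

Compound 3 stands second highest of the three numbers; its nearest neighbour is compound 2, and the step of a 1.2-fold higher number from compound 2 to compound 3 (0.06 log units; within the scatter) lies within the scatter, so the two cannot be told apart. Compound 1 sits a little higher than compound 3, again within the scatter, so all three values form one cluster.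

Compound 4, `CCCCCCCc1nc(N)n(CC(=O)Nc2ccc(C)cc2)c1-c1ccccc1Br`, is compound 3 with the change (methyl in place of hydrogen on a saturated chain carbon, six bonds along the chain from an aromatic carbon). For the measured compounds named here, the one measured step that bears on it is the preceding lengthening of the same chain, a 1.2-fold higher number from compound 2 to compound 3 (0.06 log units; within the scatter), which did nothing beyond the scatter. Compound 1 also carries the longer chain, with a different amide substituent, and its value sits in the same cluster, which gives no sign of a move in either direction.

On this basis compound 4 is expected to stay close to compound 3, with the step of a 1.1-fold higher number from compound 3 to compound 4 (0.03 log units; within the scatter) estimated to fall within the scatter. Compound 4 is therefore estimated at 7000 nM, with a likely range from 3500 nM to 14000 nM.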

Compound 4, half-maximal inhibitory concentration: 7000 nM
Estimate against measurement, compound 4: no gap at the digits printed; the measured number falls inside the stated range.
By their numbers in this assay, from the lowest: compounds 2, 3, 4 and 1 (each within the scatter of the next).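

In this assay the methyl in place of hydrogen on a saturated chain carbon, six bonds along the chain from an aromatic carbon, comes with a 1.1-fold higher number from compound 3 to compound 4 (0.03 log units; within the scatter) and so adds a second single-carbon extension that cannot be told apart from no extension. The larger replacement, ethyl in place of hydrogen five bonds along the chain, comes with a 1.3-fold higher number from compound 2 to compound 4 (0.10 log units; within the scatter) and also stays within the scatter, which the single-carbon step alone could not show. The methyl in place of hydrogen on an aromatic carbon can now be read on this same chain, with a 1.1-fold lower number from compound 1 to compound 4 (0.05 log units; within the scatter) again within the scatter, and nothing in the material at hand offers a reason for these readings.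

The compounds shown leave open whether a much shorter chain such as propyl, or a longer chain than that of compound 4, would move the number beyond the scatter. They also leave open what an amine or a carboxylic acid at the chain end would do, or a methoxy or chloro group in place of the methyl on the aromatic carbon.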